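The source may report more compounds than this note shows. Statements on the series, on what has been measured and on what is new or still open speak of the compounds shown alone.

Among the compounds with values here, in a functional assay for inhibition (a higher number here means a weaker inhibitor, a lower number a stronger inhibitor), three compounds that share one core have numbers so far. Compound 1 `CC(C)(C)c1cc(-c2cc(=O)c3ccc(OCC(=O)N4CCN(Cc5ccccc5)CC4)cc3o2)cc(C(C)(C)C)c1O` gives 3000 nM and compound 2 `CC(C)(C)c1cc(-c2cc(=O)c3ccc(OCc4ccc5ccccc5n4)cc3o2)cc(C(C)(C)C)c1O` gives 3000 nM, so these two stand level, and together they hold the highest number of the three. Compound 3 `CN(C)CCCOc1ccc2c(=O)cc(-c3cc(C(C)(C)C)c(O)c(C(C)(C)C)c3)oc2c1` gives 700 nM.

The unmeasured compound 4 `CCOC(=O)C(C)(C)Oc1ccc2c(=O)cc(-c3cc(C(C)(C)C)c(O)c(C(C)(C)C)c3)oc2c1` departs from compound 2 in one place: 1-(ethoxycarbonyl)-1-methylethyl in place of (quinolin-2-yl)methyl on an oxygen on an aromatic ring. In words, 1-(ethoxycarbonyl)-1-methylethyl takes the place of (quinolin-2-yl)methyl on an oxygen on an aromatic ring.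

Within the data shown here, one measured step bears directly on this change. It also removes quinolin-2-yl, putting 2-(dimethylamino)ethyl in its place. That step is a 4.3-fold lower number from compound 2 to compound 3 (0.63 log units; beyond the scatter). Compound 1 is a caution, since it carries yet another group on that oxygen and compound 2 still matches compound 1 at 3000 nM. A new group here therefore need not move the number. Among the measured compounds shown here, no measured compound carries the ethoxycarbonyl group, so the evidence is indirect.

A modest fall is expected, smaller than the step to compound 3. The estimated change is a 2.3-fold lower number from compound 2 to compound 4 (0.36 log units; beyond the scatter), read in this assay. For compound 4 the expected value is 1300 nM, with an estimated range of 450 nM to 3500 nM.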

Compound 4, half-maximal inhibitory concentration: 3000 nM
Estimate against measurement, compound 4: 2.3-fold (0.36 log units) below; the measured number falls inside the stated range.
By their numbers in this assay, from the lowest: compound 3; then compounds 1, 2 and 4 (each within the scatter of the next).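

In this assay, replacing the two-ring (quinolin-2-yl)methyl with the ringless 1-(ethoxycarbonyl)-1-methylethyl on this oxygen gives no change at the digits printed from compound 2 to compound 4 (within the scatter), so this position tolerates the loss of the aromatic rings without any measurable shift in the number. Within the data shown here, replacing 3-(dimethylamino)propyl with the same group gives a 4.3-fold higher number from compound 3 to compound 4 (0.63 log units; beyond the scatter), which leaves compound 3 as the only one of the four compounds set apart from the others, while three quite different groups on this oxygen, in compounds 1, 2 and 4, all read alike. No accompanying measurement accounts for why compound 3 stands apart from the rest.

On these data alone, it remains open whether a carboxylic acid in place of the ethyl ester of compound 4 would read differently from compound 4. As far as these compounds go, it is also open whether the lower number of compound 3 would persist with a longer chain such as 4-(dimethylamino)butyl, or with a ring amine such as morpholine at the end of the 3-carbon chain.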